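This account rests on a few compounds, and the source may have more. Where it says the series, first, only, none or still open, it means among the compounds named here.

Measured compounds in a functional assay (MiaPaCa cells, Homo sapiens) for inhibition, read by sulforhodamine B assay, with a stated time of 48 h; a higher number here means a weaker inhibitor of growth, a lower number a stronger inhibitor of growth:
compound 1 `O=C(N/N=C\c1ccc(Cl)cc1)C1=C(Cl)c2ccccc2CCC1` gives < 10 nM
compound 2 `O=C(N/N=C\c1ccc(F)cc1)C1=C(Cl)c2ccccc2CCC1` gives < 10 nM
compound 3 `Cc1cc2c(cc1C)C(Cl)=C(C(=O)N/N=C\c1ccc(Cl)cc1)CCC2` gives 440 nM

The value of compound 1 in this assay is a limit of the assay, not a number. The value of compound 2 is likewise a limit. Compound 3, which carries two added methyl groups on its core, is the only one of the three with a number. The difference between the core of compound 1 and the core of compound 3 is not broken down here.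

Compound 4 `Cc1cc2c(cc1C)C(Cl)=C(C(=O)N/N=C\c1ccc(F)cc1)CCC2` has not yet been measured in this assay. It stands to compound 3 as compound 2 stands to compound 1: fluoro in place of chloro on an aromatic carbon The change from compound 1 to compound 2 is the same one: fluoro in place of chloro on an aromatic carbon Its measured size is a step that the two limits leave unreadable from compound 1 to compound 2, which rests on (the limit of < 10 nM in this assay, at which 2 of the 3 values shown sit). So the pair that has been measured tells nothing about the direction or size of this change, and there is no basis for expecting compound 4 to move far from compound 3.

He therefore estimates that the step of a 1.0-fold lower number from compound 3 to compound 4 (0.02 log units; within the scatter) is expected to stay within the usual scatter. Compound 4 is expected to give about 420 nM in this assay, with the estimate spanning from 150 nM to 1200 nM.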

Compound 4, concentration for 50% growth inhibition: 360 nM
Compound 4: middle estimate off by 1.2-fold (0.07 log units), on the high side, within the range that was stated.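

In this assay, on the core that carries the two added methyl groups, fluoro in place of chloro gives a 1.2-fold lower number from compound 3 to compound 4 (0.09 log units; within the scatter), so on this core 4-chlorophenyl and 4-fluorophenyl cannot be told apart. From the compounds shown here alone, on the core of compound 1 the same change cannot be read, because compound 1 and compound 2 each give a limit of the assay and not a number: the limit of < 10 nM in this assay, at which 2 of the 4 values shown sit. The series therefore offers one readable instance of this change, which shows that it makes no difference beyond the scatter on the core of compound 3 but does not show that the result carries over to the core of compound 1, where the size and direction of the step remain unknown.

The compounds shown leave open whether a group other than these two halogens at the same place on the aromatic ring, such as a methoxy, a nitrile or an amine, would shift the number on the core of compound 3, where numbers can be read. They also leave open what a methoxy or a longer chain in place of the two methyl groups on the core would do in this assay.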